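Methyl for chloro on the aryl ring of compound 1

The source may hold more compounds than are shown below. What is called first, only, known or untested is meant among the compounds shown, and "the series" means these compounds.

Measured so far in an ADME assay on BHK-21 cells (Mesocricetus auratus) for cytotoxicity, read by MTT assay, with a stated time of 72 h; a lower number here means that less compound is tolerated, a higher number that more compound is tolerated:
compound 1 `Clc1ccc(NCc2cn(-c3ccccc3)nc2-c2ccc(Cl)cc2)cc1` – 73000 nM
compound 2 `Cc1ccc(NCc2cn(-c3ccccc3)nc2-c2ccc(Cl)cc2)cc1` – > 100000 nM
compound 3 `FC(F)(F)c1ccc(NCc2cn(-c3ccccc3)nc2-c2ccc(C(F)(F)F)cc2)cc1` – 27000 nM

Compound 1 gives the highest of the two plain numbers in this assay; the nearest is compound 3, which sits a good deal lower, and that gap is beyond the usual scatter. Compound 2 gives no number in this assay but a limit, > 100000 nM, which is the assay's own ceiling (the limit of > 100000 nM in this assay, at which 1 of the 3 values shown sits).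

Compound 4 `Cc1ccc(-c2nn(-c3ccccc3)cc2CNc2ccc(Cl)cc2)cc1` is the next step from compound 1. The difference is methyl in place of chloro on an aromatic carbon. Among the compounds with values here, the only measured step of the same kind is an at least 1.3-fold higher number from compound 1 to compound 2 (0.13 log units; that floor lies within the scatter), where the methyl entered on the other aromatic ring of the shared core and the number rose to a limit, so its true size is not fixed. On that basis a rise in this assay for compound 4 is expected rather than a fall, but its size is uncertain and could be small.

The value expected for compound 4 in this assay is 100000 nM, within 50000 nM to 200000 nM. The step this means, a 1.4-fold higher number from compound 1 to compound 4 (0.14 log units; within the scatter), is an estimate, and the number may again come back as a limit.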

Compound 4, half-maximal cytotoxic concentration: > 100000 nM
Compound 4 was reported as a limit; the forecaster's own chance of this, stated with the estimate: 45%; the middle value sits exactly at the limit.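

In this assay, the change from 4-chlorophenyl to 4-methylphenyl on the shared core gives an at least 1.3-fold higher number from compound 1 to compound 4 (0.13 log units; that floor lies within the scatter), so methyl in place of chloro now has a second reading, on a different aromatic ring from the one changed in an at least 1.3-fold higher number from compound 1 to compound 2 (0.13 log units; that floor lies within the scatter). Within the data shown here, compound 4 gives only a limit, > 100000 nM, and so the change at this position has no fixed size; since the floor lies within the scatter, it shows no established rise, only that no lower number appeared at either position. The two methyl compounds therefore end at the same ceiling: the limit of > 100000 nM in this assay, at which 2 of the 4 values shown sit.

The true values of compound 2 and compound 4 remain unknown, so the compounds shown cannot tell whether the change counts for more at one position than at the other, or whether any measurable difference from compound 1 exists. Also open, as far as these compounds go, is how this position responds to a group of another kind, such as an amine, a carboxylic acid or a longer chain, and whether any such group brings the number back under the ceiling.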